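Swapping a pyrazole for a methoxyphenyl on the ether chain

The source may report more compounds than this note shows. Statements on the series, on what has been measured and on what is new or still open speak of the compounds shown alone.

Measured so far:
Compound 1 `Cc1cc(C)n(CCOC2CC(=O)Nc3c2c(C)nn3-c2ncnc3nc[nH]c23)n1` in a functional assay on HEK293 cells for agonist activity at G-protein coupled receptor 39 (Homo sapiens), read by scintillation proximity assay and inositol phosphate accumulation, with a stated time of 75 min, in the presence of a further agent that is not named here (a lower number here means that less compound is needed, a higher number that more compound is needed for the effect), gives 16 nM.
Compound 2 `Cc1nn(-c2ncnc3nc[nH]c23)c2c1C(OCc1ccccc1C#N)CC(=O)N2` gives 8 nM.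
Compound 3 `Cc1nn(-c2ncnc3nc[nH]c23)c2c1C(OCCn1nccc1C)CC(=O)N2` gives 10 nM.

All three share one core and differ only in the group hanging from the ether chain. Compound 3 sits close to both neighbours: a 1.3-fold higher number from compound 2 to compound 3 (0.10 log units; within the scatter) and a 1.6-fold lower number from compound 1 to compound 3 (0.20 log units; within the scatter). Compound 4 `COc1ccc(CCOC2CC(=O)Nc3c2c(C)nn3-c2ncnc3nc[nH]c23)cc1` carries the change (4-methoxyphenyl in place of 5-methyl-1H-pyrazol-1-yl on a saturated chain carbon, two bonds along the chain from an oxygen on a saturated carbon). The two steps that bear on this are a 2.0-fold lower number from compound 1 to compound 2 (0.30 log units; within the scatter) and a 1.3-fold higher number from compound 2 to compound 3 (0.10 log units; within the scatter), both exchanges of a pyrazole-type group for a substituted phenyl at the same place, and neither moved the number beyond the scatter. The expected step is therefore a 1.2-fold higher number from compound 3 to compound 4 (0.08 log units; within the scatter), with no clear direction. Compound 4 is estimated at 12 nM, within 4 nM to 40 nM.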

Compound 4, half-maximal effective concentration: 2 nM
Compound 4: middle estimate off by 6.0-fold (0.78 log units), on the high side, outside the stated range (below it).
By their numbers in this assay, from the lowest: compound 4; then compounds 2, 3 and 1 (each within the scatter of the next).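

For the compounds shown here, there is a 5.0-fold lower number from compound 3 to compound 4 (0.70 log units; beyond the scatter) and a 4.0-fold lower number from compound 2 to compound 4 (0.60 log units; beyond the scatter) and an 8.0-fold lower number from compound 1 to compound 4 (0.90 log units; beyond the scatter) on moving to the 4-methoxyphenyl group, and these are the first steps beyond the scatter. The group on the ether chain can therefore shift the number clearly, although compounds 1, 2 and 3 lie within the scatter of one another. Nothing measured here explains the change.

Going by these compounds, it remains open whether the methoxy group or the benzene ring carries the effect, which a plain phenyl or a 4-hydroxyphenyl could separate. On these data alone, how an amine or a longer chain would behave here is also open.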